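This account rests on a few compounds, and the source may have more. Where it says the series, first, only, none or still open, it means among the compounds named here.

Measured compounds: compound 1 `COc1nc2ccc(Br)cc2cc1C(c1ccccc1)n1cc(-c2ccccc2F)nn1` with 14.7%; compound 2 `CCCCc1cn(C(c2ccccc2)c2cc3cc(Br)ccc3nc2OC)nn1` with 5.46%; compound 3 `COc1nc2ccc(Br)cc2cc1C(c1ccccc1)n1cc(-c2cccc(F)c2)nn1` with 15.5%, all in an ADME assay on PANC-1 cells (Homo sapiens) for cytotoxicity, read by sulforhodamine B assay, with a stated time of 48 h, tested at 10 uM; on this read-out higher numbers stand for more inhibition at the one concentration tested (going by the name of the read-out) and lower numbers for less inhibition.

Compound 3 has the highest of the three numbers, though both gaps lie within the scatter, the smaller to compound 1 and the larger to compound 2. Compound 4 `COc1nc2ccc(Br)cc2cc1C(c1ccccc1)n1cc(CCCCCO)nn1` differs from compound 3 by 5-hydroxypentyl in place of 3-fluorophenyl on an aromatic carbon. Among the measured compounds shown here, two steps bear on exchanging a fluorophenyl for a chain: a number 9.2 percentage points lower from compound 1 to compound 2 (within the scatter) and a number 10 percentage points higher from compound 2 to compound 3 (within the scatter). Neither exceeds the scatter, so for this assay no step beyond the scatter is expected, perhaps a slight decrease, giving an expected a number 7.5 percentage points lower from compound 3 to compound 4 (within the scatter). Compound 4 is therefore estimated at 8%, in the range 0% to 20%.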

Compound 4, a percentage reported as inhibition, at one concentration (the size of the read-out at that concentration, not a potency): 19.6%
The estimate for compound 4 lay 11.6 percentage points below the measured number; the range from low to high includes it.
By their numbers in this assay, from the lowest: compounds 2, 1, 3 and 4 (each within the scatter of the next, the first and the last beyond it).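

In this assay the aromatic ring at this carbon can be exchanged for the 5-hydroxypentyl chain without a step beyond the scatter, the two exchanges giving a number 4.1 percentage points higher from compound 3 to compound 4 (within the scatter) and a number 4.9 percentage points higher from compound 1 to compound 4 (within the scatter). Among the compounds shown here, the chains are not interchangeable here: hydroxymethyl in place of hydrogen on the saturated chain gives a number 14.1 percentage points higher from compound 2 to compound 4 (beyond the scatter), the first step in this set beyond the scatter. No available evidence accounts for that step. On these data alone, it remains open whether the hydroxyl or the chain length carries this difference, and how an amine or a carboxylic acid at the chain end, or a longer chain, would read.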